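The source may hold more compounds than are shown below. What is called first, only, known or untested is meant among the compounds shown, and "the series" means these compounds.

Measured so far:
- compound 1 `C=C1[C@H](OCC(C)C)C[C@@H](OC(=O)c2cccnc2)C(C)(C)/C=C/[C@@H](C)C(=O)[C@@]2(OC(C)=O)C[C@H](C)[C@H](OC(C)=O)[C@@H]2[C@H]1OC(C)=O`: 16.4%
- compound 2 `C=C1[C@H](OCC(C)C)C[C@@H](OC(=O)c2cccnc2)C(C)(C)/C=C/[C@@H](C)C(=O)[C@@]2(OC(C)=O)C[C@@](C)(OC(C)=O)[C@H](OC(C)=O)[C@@H]2[C@H]1OC(C)=O`: 26.6%

In a functional assay on Ishikawa cells (Homo sapiens) for inhibition, read by MTT assay, with a stated time of 72 h, tested at 30 ug/mL (on this read-out higher numbers stand for more inhibition of growth at the one concentration tested and lower numbers for less inhibition of growth), compound 2 gives 26.6%, the higher of the two numbers. Compound 1 gives 16.4%, and the gap between the two lies beyond the usual scatter.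

The next compound is compound 3 `C=C1[C@H](OC(C)=O)C[C@@H](OC(=O)c2cccnc2)C(C)(C)/C=C/[C@@H](C)C(=O)[C@@]2(OC(C)=O)C[C@@](C)(OC(C)=O)[C@H](OC(C)=O)[C@@H]2[C@H]1OC(C)=O`, which is to be measured in this assay. It differs from compound 2 as follows: acetyl in place of isobutyl on an oxygen on a saturated carbon. Going by the values given here, no measured pair shows this change, so its direction remains open and any expectation is weakly grounded. A small fall is expected at most, with no step beyond the scatter. The estimated a number 3.6 percentage points lower from compound 2 to compound 3 (within the scatter) is expected to stay within the scatter. Compound 3 is expected to give 23%, within an estimated range of 9% to 40%.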

Compound 3, percent growth inhibition at one concentration: 13.9%
Compound 3: the middle estimate sits 9.1 percentage points above what was measured, within the range that was stated.
By their numbers in this assay, from the lowest: compounds 3 and 1 (each within the scatter of the next); then compound 2.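

In this assay, the change from isobutoxy to acetoxy on the oxygen on a saturated carbon gives a number 12.7 percentage points lower from compound 2 to compound 3 (beyond the scatter), the first step read at this position. The position therefore does not tolerate every group equally at the one concentration tested, and of the two groups shown, isobutyl goes with the greater inhibition of growth. The step rests on a single pair, and nothing measured here accounts for it.

This change alters both the link to the oxygen, from ether to ester, and the chain, so the pair cannot separate the two; a methyl ether or an isobutyryl ester on the same oxygen would bear on that. On these data alone, how a free hydroxyl or a longer chain such as hexyl would read at this place also stays open.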